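The source may hold more compounds than are shown below. What is called first, only, known or untested is meant among the compounds shown, and "the series" means these compounds.

Of the compounds shown here, two built on the same core have been tested in a functional assay on HL-60 cells (Homo sapiens) for antiproliferative activity, with a stated time of 24 h; on this read-out higher numbers stand for weaker inhibition and lower numbers for stronger inhibition. Compound 1 `N#Cc1ccccc1CN1CCc2c(sc(NC(=O)c3ccccc3Cl)c2C(N)=O)C1` gives 10400 nM in this assay. Compound 2 `NC(=O)c1c(NC(=O)c2ccccc2Cl)sc2c1CCN(C(=S)Nc1ccccc1-c1ccccc1)C2` gives 34400 nM in this assay, the higher of the two numbers, and the gap between compound 2 and compound 1 lies beyond the usual scatter of repeated measurements, so compound 2 is the weaker inhibitor of this pair. The two structures differ in more than one place, so the gap cannot be tied to any single change.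

Compound 3 `NC(=O)c1c(NC(=O)c2ccccc2Cl)sc2c1CCN(C(=S)Nc1cccnc1)C2` differs from compound 2 in one place only: pyridin-3-yl in place of 2-phenylphenyl on an amide-type nitrogen. The group that enters is smaller than the one that leaves and brings a hydrogen-bond acceptor where the leaving group had none. For the measured compounds named here, no measured pair here shows what such a swap does, so its direction is open. The step in this assay is expected to be small, most likely within the scatter, giving a 1.1-fold lower number from compound 2 to compound 3 (0.06 log units; within the scatter). Compound 3 is therefore estimated at 30000 nM, with an expected range from 8000 nM to 110000 nM.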

Compound 3, half-maximal inhibitory concentration: 33900 nM
For compound 3 the middle estimate is 1.1-fold (0.05 log units) below the measured one; the range from low to high includes it.
By their numbers in this assay, from the lowest: compound 1; then compounds 3 and 2 (each within the scatter of the next).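

In this assay, the step on the amide-type nitrogen is a 1.0-fold lower number from compound 2 to compound 3 (0.01 log units; within the scatter) and stays within the scatter, so 2-phenylphenyl and the smaller pyridin-3-yl, which adds a hydrogen-bond acceptor, cannot be told apart at this position. Even this large swap of the group on that nitrogen leaves the read-out unmoved for this pair, while changing the whole group on the amine nitrogen in the ring gives a 3.3-fold higher number from compound 1 to compound 3 (0.51 log units; beyond the scatter) and goes beyond the scatter, although the size of that step is modest. No measurement here offers an explanation for either result.

From the compounds shown here alone, both compounds with the thiocarbonyl unit carry an aromatic ring on the amide-type nitrogen, so it remains open whether a non-aromatic group there, such as a short ethyl chain or a chain ending in an amine or a carboxylic acid, would also leave the number in place. Going by these compounds, it also remains open whether the step from the group on the ring nitrogen of compound 1 depends on the thiocarbonyl itself, which a carbonyl in its place would test.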